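Moving the chlorine around the benzyl ring: compound 4

This account rests on a few compounds, and the source may have more. Where it says the series, first, only, none or still open, it means among the compounds named here.

Of the compounds shown here, three sharing one core have been tested in a functional assay on the whole organism (artery, strain albino) with Rattus norvegicus as the target, with a stated time of 240 min, at a dose of 10 mg/kg by the oral route; a lower number here means less inhibition, a higher number more inhibition at the dose given (going by the name of the read-out). Compound 1 `CC1=C(C(=O)Nc2ccc([N+](=O)[O-])cc2)C(c2cccc([N+](=O)[O-])c2)N=C(SCc2ccccc2)N1` gives 21%. Compound 2 `CC1=C(C(=O)Nc2ccc([N+](=O)[O-])cc2)C(c2cccc([N+](=O)[O-])c2)N=C(SCc2ccccc2Cl)N1` gives 12.8%, and compound 3 `CC1=C(C(=O)Nc2ccc([N+](=O)[O-])cc2)C(c2cccc([N+](=O)[O-])c2)N=C(SCc2cccc(Cl)c2)N1` gives 17.9%. Compound 3 stands with its two neighbours inside the usual scatter: one gap is a number 3.1 percentage points lower from compound 1 to compound 3 (within the scatter), and the other gap is a number 5.1 percentage points higher from compound 2 to compound 3 (within the scatter), so no real separation between the three is shown.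

Compound 4 `CC1=C(C(=O)Nc2ccc([N+](=O)[O-])cc2)C(c2cccc([N+](=O)[O-])c2)N=C(SCc2ccc(Cl)cc2)N1` differs from compound 3 only in where the chlorine sits on the benzyl ring: 4-chlorophenyl in place of 3-chlorophenyl on a saturated chain carbon bound to a sulfur. Among the compounds with values here, the only measured step that moves the chlorine on this ring is the one from compound 2 to compound 3, a number 5.1 percentage points higher from compound 2 to compound 3 (within the scatter), and adding the chlorine at all, a number 8.2 percentage points lower from compound 1 to compound 2 (within the scatter) or a number 3.1 percentage points lower from compound 1 to compound 3 (within the scatter), also stayed within the scatter. Shifting it once more is therefore expected to give no step beyond the scatter, a number 0.9 percentage points lower from compound 3 to compound 4 (within the scatter) in this assay. Compound 4 is estimated at 17%, expected to lie between 8% and 27%.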

Compound 4, a percentage reported as inhibition, in the whole organism at one dose (the size of the read-out at that dose, not a potency): 20%
Compound 4: the middle estimate sits 3 percentage points below what was measured; the range from low to high includes it.
By their numbers in this assay, from the lowest: compounds 2, 3, 4 and 1 (each within the scatter of the next).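

With 4-chlorophenyl now measured alongside 2-chlorophenyl and 3-chlorophenyl, the position of the chlorine on the benzyl ring can be compared across all three forms in this assay: the steps read a number 2.1 percentage points higher from compound 3 to compound 4 (within the scatter) and a number 7.2 percentage points higher from compound 2 to compound 4 (within the scatter), so none of these forms separates from another. Against the benzyl group without chlorine, the step is a number 1 percentage points lower from compound 1 to compound 4 (within the scatter), so chloro in place of hydrogen on this ring stays within the scatter for all three chlorinated compounds. No evidence here bears on why these numbers fall as they do.

As far as these compounds go, whether a different group on this ring, such as an amine or a carboxylic acid, would give a step beyond the scatter remains open. The same holds for a longer chain in place of the benzyl group on the sulfur.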